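Trading dichlorophenyl for dimethoxyphenyl on a pyrazolyl chalcone

The source may hold more compounds than are shown below. What is called first, only, known or untested is meant among the compounds shown, and "the series" means these compounds.

Compound 1 `COc1cc(-c2cc(/C=C/C(=O)c3ccc(Cl)c(Cl)c3)[nH]n2)cc(OC)c1OC` was tested in a functional assay on OVCAR-3 cells (Homo sapiens) for cytotoxicity, read by sulforhodamine B assay, with a stated time of 48 h, tested at 0.1 uM (on this read-out higher numbers stand for a weaker effect at the one concentration tested and lower numbers for a stronger effect), and gave 105%. Compound 2 `COc1ccc(-c2cc(/C=C/C(=O)c3cc(OC)c(OC)c(OC)c3)[nH]n2)cc1OC` gave 100% in this assay, and compound 3 `COc1ccc(-c2cc(/C=C/C(=O)c3ccc(N)cc3)[nH]n2)cc1` gave 96%. Compound 1 thus holds the highest of the three numbers, but its gaps to compound 2 and to compound 3 both lie within the usual scatter of repeated measurements, so no one of the three can be set apart from the others.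

Compound 4 `COc1ccc(C(=O)/C=C/c2cc(-c3cc(OC)c(OC)c(OC)c3)n[nH]2)cc1OC` has not been measured. It differs from compound 1 in one place: 3,4-dimethoxyphenyl in place of 3,4-dichlorophenyl on a carbonyl carbon. Since none of the three measured compounds shows a clear effect at this concentration, the step from compound 1 to compound 4 is expected to stay within the scatter, at a number 6 percentage points lower from compound 1 to compound 4 (within the scatter). Compound 4 is therefore estimated at 99%, with a range from 88% to 110%.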

Compound 4, a percentage reported as activity, at one concentration (the size of the read-out at that concentration, not a potency): 100%
For compound 4 the middle estimate is 1 percentage points below the measured one, within the range that was stated.
By their numbers in this assay, from the lowest: compounds 3, 2, 4 and 1 (each within the scatter of the next).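

Among these compounds, this pair is the first in the set to differ in one place, and in this assay the exchange of 3,4-dichlorophenyl for 3,4-dimethoxyphenyl on a carbonyl carbon reads as a number 5 percentage points lower from compound 1 to compound 4 (within the scatter) at the one concentration tested. At this position, then, the two groups cannot be told apart, even though the entering group brings hydrogen-bond acceptors that the leaving group lacks. No evidence on hand gives a reason for this result. As far as these compounds go, whether a carboxylic acid or a morpholine in that place would give a number set apart from these, and whether the two groups would separate at other concentrations, remains open.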